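This account rests on a few compounds, and the source may have more. Where it says the series, first, only, none or still open, it means among the compounds named here.

Measured so far in an assay on Sf9 cells for inhibition of protein deacetylase HDAC6 (Homo sapiens), read by fluorescence, with a stated time of 40 min, tested at 100 nM; a lower number here means less inhibition, a higher number more inhibition at the concentration tested (going by the name of the read-out):
- compound 1, `O=C(NO)c1ccc(NCc2nc(-c3ccc(Cl)cc3)nn2-c2ccccc2)cc1`, gives 67.2%
- compound 2, `O=C(NO)c1ccc(NCc2nc(-c3ccccc3)nn2-c2cccc(Cl)c2)cc1`, gives 62.3%
- compound 3, `NNC(=O)c1ccc(NCc2nc(-c3ccccc3)nn2-c2ccccc2)cc1`, gives 10%

Compound 1 has the highest of the three numbers in this assay. Its nearest neighbour is compound 2, whose number lies within the scatter of that of compound 1, so no order can be read between those two. Compound 3 is the furthest away, its number being far lower than that of compound 1 and well beyond the scatter.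

The step under consideration leads from compound 1 to compound 4, `O=C(NO)c1ccc(NCc2nc(-c3ccsc3)nn2-c2ccccc2)cc1`, which has not yet been measured in this assay. The change between them is thiophen-3-yl in place of 4-chlorophenyl on an aromatic carbon. Within the data shown here, no pair of measured compounds differing in a single place is available, so there is no measured step to lean on. Compounds 1 and 2 show that the two aromatic groups on the shared core can carry or lack a chlorine with numbers that stay within the scatter of each other. On that basis compound 4 is expected to come out close to compound 1, with the step of a number 9.2 percentage points lower from compound 1 to compound 4 (within the scatter) expected to stay within the scatter, though a small loss is thought somewhat more likely than a gain. The estimate for compound 4 in this assay is 58%, with a range from 40% to 75%.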

Compound 4, a percentage reported as inhibition, at one concentration (the size of the read-out at that concentration, not a potency): 53.4%
For compound 4 the middle estimate is 4.6 percentage points above the measured one, and the stated range covers the measured number.
By their numbers in this assay, from the lowest: compound 3; then compounds 4, 2 and 1 (each within the scatter of the next, the first and the last beyond it).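

In this assay, among these compounds, placing thiophen-3-yl instead of 4-chlorophenyl on the aromatic carbon between two ring nitrogen atoms gives the first single-place change that can be read, and it comes out as a number 13.8 percentage points lower from compound 1 to compound 4 (beyond the scatter). This shows that the position is not indifferent to the group it carries, since exchanging this one aromatic group while the rest of the molecule stays the same moves the number beyond the usual scatter, yet the step is modest and compound 4 still gives 53.4% at the concentration tested. No measurement at hand bears on why the number falls with this change.

The compounds shown leave open whether the step belongs to the loss of the chlorine or to the exchange of the six-membered ring for the five-membered one, a question that a plain phenyl group at this place, set against compound 1 and compound 4, would separate. Also open, from the compounds shown here alone, is how this assay would read with a furan-3-yl group, a pyridine ring or an amine on this same carbon.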